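Triazole for methylpiperazine on a pyrazoline series

The compounds below may be only part of what the source reports. "The series", "measured", "known", "first", "only" and "open" are said of these compounds alone.

Measured so far:
compound 1 `CN(C)c1ccc(C2CC(c3ccc(-n4cncn4)cc3)=NN2)cc1`, 6.8%
compound 2 `CC(=O)N1N=C(c2ccc(N3CCN(C)CC3)cc2)CC1c1ccc(N(C)C)cc1`, -0.8%

In a functional assay on HCC1806 cells (Homo sapiens) for inhibition, read by sulforhodamine B assay, tested at 10 uM (on this read-out higher numbers stand for more inhibition at the one concentration tested (going by the name of the read-out) and lower numbers for less inhibition), compound 1 gives 6.8% and compound 2 gives -0.8%. Compound 2 sits at the bottom of the two numbers, yet its gap to compound 1 is within the scatter, so the two cannot be told apart. Compound 3 `CC(=O)N1N=C(c2ccc(-n3cncn3)cc2)CC1c1ccc(N(C)C)cc1` has not been measured. Compound 3 differs from compound 2 by 1H-1,2,4-triazol-1-yl in place of 4-methylpiperazin-1-yl on an aromatic carbon. Among the measured compounds shown here, no step between measured compounds is known here. The step of a number 3.8 percentage points higher from compound 2 to compound 3 (within the scatter) is expected to be none beyond the scatter. For compound 3 the estimate in this assay is 3%, with a range from -8% to 15%.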

Compound 3, a percentage reported as inhibition, at one concentration (the size of the read-out at that concentration, not a potency): 11%
The estimate for compound 3 lay 8 percentage points below the measured number; the measured number falls inside the stated range.
By their numbers in this assay, from the lowest: compounds 2, 1 and 3 (each within the scatter of the next, the first and the last beyond it).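

In this assay, among the compounds shown here, 1H-1,2,4-triazol-1-yl in place of 4-methylpiperazin-1-yl on the aromatic carbon gives a number 11.8 percentage points higher from compound 2 to compound 3 (beyond the scatter), the first modest step at this position, seen so far in a single pair. Acetyl in place of hydrogen on the ring amine nitrogen gives a number 4.2 percentage points higher from compound 1 to compound 3 (within the scatter), so that change has no readable effect here. Nothing available bears on why the triazole step occurs.

Going by these compounds, whether a morpholine or a carboxylic acid at this position would move the number further remains open. So does whether a longer acyl chain would differ from acetyl.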